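Swapping a branched alkyl chain for a straight pentyl

This account rests on a few compounds, and the source may have more. Where it says the series, first, only, none or still open, it means among the compounds named here.

Compound 2 `COC(=O)c1cccc(NC(=O)COc2ccc(C(C)(C)CC(C)(C)C)cc2)c1` is a methyl ester joined through an amide and an ether oxygen to a ring that carries a 1,1,3,3-tetramethylbutyl group. In an assay for inhibition of malate dehydrogenase, cytoplasmic (Homo sapiens), with a stated time of 30 min (a higher number here means a weaker inhibitor, a lower number a stronger inhibitor), compound 2 gives 6650 nM, the second highest of three numbers. For the measured compounds named here, compound 1 `COCCOc1ccc(C(=O)OC)cc1NC(=O)COc1ccc(C(C)(C)CC(C)(C)C)cc1` gives 18400 nM, and the one measured step, a 2.8-fold lower number from compound 1 to compound 2 (0.44 log units; beyond the scatter), concerns a different position. Compound 3 `COC(=O)c1ccc(O)c(NC(=O)CCOc2ccc(C(C)(C)CC(C)(C)C)cc2)c1` gives 1540 nM, but no single change links it to the others. Compound 4 `CCCCCc1ccc(OCC(=O)Nc2cccc(C(=O)OC)c2)cc1` differs from compound 2 by pentyl in place of 1,1,3,3-tetramethylbutyl on an aromatic carbon. Going by the values given here, no measured step touches this alkyl chain, so the expectation for compound 4 rests on compound 2 alone, with a modest weakening expected, a 1.5-fold higher number from compound 2 to compound 4 (0.18 log units; within the scatter). Compound 4 is therefore estimated at 10000 nM in this assay, within 3000 nM to 35000 nM.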

Compound 4, half-maximal inhibitory concentration: 6790 nM
Estimate against measurement, compound 4: 1.5-fold (0.17 log units) above; measured number inside the range.
By their numbers in this assay, from the lowest: compound 3; then compounds 2 and 4 (each within the scatter of the next); then compound 1.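

For the compounds shown here, this is the first look at the alkyl group on this aromatic carbon: in this assay, pentyl in place of 1,1,3,3-tetramethylbutyl gives a 1.0-fold higher number from compound 2 to compound 4 (0.01 log units; within the scatter), so the two numbers cannot be told apart. For this pair, then, the branched group can give way to the straight chain with no measurable difference. Nothing available explains why the two groups read alike. Going by these compounds, whether methyl, a longer chain such as octyl, or a cyclohexyl ring would also leave the number in place remains open.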